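The source may hold more compounds than are shown below. What is called first, only, known or untested is meant among the compounds shown, and "the series" means these compounds.

Compound 1, `O=C(/C(=C/c1ccc(Cl)cc1Cl)CCl)c1ccccc1`: 6300 nM
Compound 2, `CC(=O)OC/C(=C\c1ccc(Cl)cc1)C(=O)c1ccccc1`: 5300 nM

Of the compounds shown here, two have been measured in a functional assay on T47D cells (Homo sapiens) for inhibition, read by sulforhodamine B assay, with a stated time of 48 h; a lower number here means a stronger inhibitor of growth, a higher number a weaker inhibitor of growth. Compound 2 gives 5300 nM in this assay, and compound 1 gives 6300 nM. Compound 2 has the lowest of the two numbers, but its nearest neighbour, compound 1, lies within the scatter, so no order between them can be read. Compound 3, `CC(=O)OC/C(=C\c1ccc(Cl)cc1Cl)C(=O)c1ccccc1`, differs from compound 2 by chloro in place of hydrogen on an aromatic carbon. For the measured compounds named here, no measured pair shows this change on its own, so only a modest step in this assay is expected, in either direction or none beyond the scatter. Compound 3 is therefore expected to give about 4500 nM, with a range of 1500 nM to 14000 nM, an estimated step of a 1.2-fold lower number from compound 2 to compound 3 (0.07 log units; within the scatter).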

Compound 3, concentration for 50% growth inhibition: 9500 nM
Compound 3: middle estimate off by 2.1-fold (0.32 log units), on the low side; the range from low to high includes it.
By their numbers in this assay, from the lowest: compounds 2, 1 and 3 (each within the scatter of the next).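

Chloro in place of hydrogen on the aromatic carbon ortho to a large group gives a 1.8-fold higher number from compound 2 to compound 3 (0.25 log units; within the scatter) in this assay, so this change at this position cannot be told from no effect. Acetoxy in place of chloro on the saturated chain carbon bound to a double-bonded chain carbon gives a 1.5-fold higher number from compound 1 to compound 3 (0.18 log units; within the scatter) and likewise cannot be told from no effect. No measurement here offers an explanation for either step. From the compounds shown here alone, whether an amine at the aromatic position, or a longer chain in place of the acetoxy, would move the number beyond the scatter remains open.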